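Coumarin amide series: terminal amine swap on propoxy chain

The compounds below may be only part of what the source reports. "The series", "measured", "known", "first", "only" and "open" are said of these compounds alone.

Measured so far:
compound 1 `CC(=O)Oc1ccc(C(=O)Nc2cc3ccc(OCCC4CCCCN4)c(C)c3oc2=O)cc1CC=C(C)C` — 710 nM
compound 2 `CCN(C)CCCOc1ccc2cc(NC(=O)c3ccc(O)c(CC=C(C)C)c3)c(=O)oc2c1C` — 2190 nM

In a functional assay on MCF7 cells (Homo sapiens) for antiproliferative activity (on this read-out higher numbers stand for weaker inhibition and lower numbers for stronger inhibition), compound 2 gives 2190 nM, the higher of the two numbers; compound 1 gives 710 nM, a gap beyond the scatter. The two differ in more than one place, so only the bare values are compared.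

Compound 3 `CC(C)=CCc1cc(C(=O)Nc2cc3ccc(OCCCNC(C)(C)C)c(C)c3oc2=O)ccc1O` is not yet measured. Its change from compound 2: (tert-butyl)amino in place of ethyl(methyl)amino on a saturated chain carbon, three bonds along the chain from an oxygen on an aromatic ring. Within the data shown here, with no single-site step available as guide, the expected change in this assay is small, toward a lower number, of a 1.5-fold lower number from compound 2 to compound 3 (0.16 log units; within the scatter). Compound 3 is estimated at 1500 nM, within 500 nM to 4500 nM.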

Compound 3, half-maximal inhibitory concentration: 950 nM
Compound 3: the middle estimate sits 1.6-fold (0.20 log units) above what was measured; low and high end bracket the measured number.
By their numbers in this assay, from the lowest: compounds 1 and 3 (each within the scatter of the next); then compound 2.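

Within this assay, swapping ethyl(methyl)amino for (tert-butyl)amino on the saturated chain carbon, three bonds along the chain from an oxygen on an aromatic ring, gives a 2.3-fold lower number from compound 2 to compound 3 (0.36 log units; beyond the scatter) and shows that the read-out responds to the terminal amine at this position. This single step cannot separate the added carbon from the hydrogen-bond donor gained. No available data explain the shift.

Still open, on these data alone, is how an isopropylamino or morpholine group on the same propyl chain would read. As far as these compounds go, the effect of a longer chain carrying (tert-butyl)amino also remains open.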